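The source may report more compounds than this note shows. Statements on the series, on what has been measured and on what is new or still open speak of the compounds shown alone.

Of the compounds shown here, three have been measured in a functional assay on the whole organism with Mus musculus as the target; a higher number here means that more compound is needed for the effect, a lower number that less compound is needed. Compound 1 `CNC(=O)/C=C1\CCc2cc(F)c(F)cc21` gives 96 mg/kg. Compound 2 `CNC(=O)/C=C1\CCc2c(F)cc(F)cc21` gives 45 mg/kg, and compound 3 `NC(=O)/C=C1\CCc2c(F)cc(F)cc21` gives 69 mg/kg. Compound 1 needs a larger dose than compound 2, a gap beyond the usual scatter of this kind of measurement, whereas its gap to compound 3 stays within that scatter, so those two cannot be ranked. Compound 2 and compound 3 differ in a single place (hydrogen in place of methyl on an amide-type nitrogen), and the step of a 1.5-fold higher number from compound 2 to compound 3 (0.19 log units; within the scatter) lies within the scatter, so this change on its own hardly moved the number. Compound 1 and compound 2 hold the same atoms joined differently; the difference between the two cores is not broken down here. The unmeasured compound 4 `NC(=O)/C=C1\CCc2cc(F)c(F)cc21` is related to compound 1 by the same change (hydrogen in place of methyl on an amide-type nitrogen), at a place described in identical words. Because the step of a 1.5-fold higher number from compound 2 to compound 3 (0.19 log units; within the scatter) was small, the step of a 1.5-fold higher number from compound 1 to compound 4 (0.16 log units; within the scatter) is expected to be of similar size. On that basis compound 4 is estimated at 140 mg/kg in this assay, most likely between 70 mg/kg and 280 mg/kg.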

Compound 4, dose for half-maximal effect: 64 mg/kg
Compound 4: the middle estimate sits 2.2-fold (0.34 log units) above what was measured; measured number outside the range, below it.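

In this assay, hydrogen in place of methyl on the amide-type nitrogen gives a 1.5-fold lower number from compound 1 to compound 4 (0.18 log units; within the scatter), so on this core too the change cannot be told apart from the ordinary spread of repeated measurements. The two steps point in opposite directions on paper, yet each step and the gap between them stay inside what such measurements can resolve: the same change on two cores in this assay, a 1.5-fold higher number (0.19 log units; within the scatter) from compound 2 to compound 3 and a 1.5-fold lower number (0.18 log units; within the scatter) from compound 1 to compound 4, 2.3-fold (0.36 log units) apart, within the scatter of two such steps

So in these two pairs the change has no detectable effect on the number, and the two cores give no sign of responding to it differently, but this does not prove that the change is truly without effect or that it would stay small on a further core. Only hydrogen and methyl appear on that nitrogen here, so the compounds shown leave open what an ethyl group, a longer chain or a ring attached there would do to the dose. They also leave open whether the step stays this small when chlorine takes the place of the fluorines on the core.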